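Thiourea aryl exchange: compound 2 to compound 3

The source may report more compounds than this note shows. Statements on the series, on what has been measured and on what is new or still open speak of the compounds shown alone.

Compound 2 `NC(=O)c1c(NC(=O)c2ccccc2Cl)sc2c1CCN(C(=S)Nc1ccccc1C(F)(F)F)C2` holds the lowest of the two numbers in a functional assay on MKN-74 cells (Homo sapiens) for antiproliferative activity, with a stated time of 24 h (a higher number here means a weaker inhibitor, a lower number a stronger inhibitor), at 1870 nM. Compound 1 `NC(=O)c1c(NC(=O)c2ccccc2Cl)sc2c1CCN(C(=S)Nc1cccc3ccccc13)C2` gives 20700 nM, and the step of an 11-fold lower number from compound 1 to compound 2 (1.04 log units; beyond the scatter) shows that the group on the amide-type nitrogen can move the number a long way. Compound 3 `NC(=O)c1c(NC(=O)c2ccccc2Cl)sc2c1CCN(C(=S)Nc1c(Cl)cccc1Cl)C2` carries 2,6-dichlorophenyl in place of 2-(trifluoromethyl)phenyl on an amide-type nitrogen. Going by the values given here, no measured step covers this exchange, so the sole step in this assay offers direction only for its own pair. Compound 3 is expected to show a step of a 1.3-fold higher number from compound 2 to compound 3 (0.13 log units; within the scatter). For compound 3 the estimate is 2500 nM, with a range from 700 nM to 9000 nM.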

Compound 3, half-maximal inhibitory concentration: 4020 nM
For compound 3 the middle estimate is 1.6-fold (0.21 log units) below the measured one, and the stated range covers the measured number.
By their numbers in this assay, from the lowest: compound 2; then compound 3; then compound 1.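

In this assay the change to 2,6-dichlorophenyl on the amide-type nitrogen gives a 2.1-fold higher number from compound 2 to compound 3 (0.33 log units; beyond the scatter) and so separates two substituted phenyl groups at this position, with 2-(trifluoromethyl)phenyl keeping the lowest number. Set against naphthalen-1-yl, the same group gives a 5.1-fold lower number from compound 1 to compound 3 (0.71 log units; beyond the scatter) and keeps most of the gain seen with the trifluoromethyl compound. No evidence at hand bears on this order. The compounds shown leave open how an unsubstituted phenyl, a methoxyphenyl or a cyclohexyl group would rank here. Going by these compounds, whether this order holds with a different group on the rest of the core also remains open.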